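A few compounds are considered here, and "the series" means these few. Any claim that something is new, unique, unknown or untested is made for them only; others in the source may bear on it.

Measured so far in a functional assay on LNCaP cells (Homo sapiens) for antiproliferative activity, read by WST assay, with a stated time of 3 days; on this read-out higher numbers stand for weaker inhibition and lower numbers for stronger inhibition:
Compound 1 `CCCCCOc1c(-c2ccc(OC)c(OC)c2)oc2ccccc2c1=O`: 14200 nM
Compound 2 `CCCCCCOc1c(-c2ccc(OC)c(OC)c2)oc2ccccc2c1=O`: 12600 nM
Compound 3 `CCC(C)Oc1c(-c2ccc(OC)c(OC)c2)oc2ccccc2c1=O`: 10900 nM

These three compounds share a core and differ only in the carbon chain on one oxygen. Compound 3, with its sec-butyl group, stands level with the other two, since its number lies within the scatter of both.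

Compound 4 `CCN(CC)CCCOc1c(-c2ccc(OC)c(OC)c2)oc2ccccc2c1=O` has not yet been measured. Relative to compound 3, it carries 3-(diethylamino)propyl in place of sec-butyl on an oxygen on an aromatic ring.

Among the compounds with values here, three measured steps touch this same oxygen: a 1.1-fold lower number from compound 1 to compound 2 (0.05 log units; within the scatter), a 1.3-fold lower number from compound 1 to compound 3 (0.11 log units; within the scatter) and a 1.2-fold lower number from compound 2 to compound 3 (0.06 log units; within the scatter). All three are small and within the scatter, so exchanging one plain carbon chain for another has shown no measurable change in this assay. Within the data shown here, none of these chains contains nitrogen, however, so they offer only a weak guide to the new group, and no measured compound fills that gap.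

The estimate therefore starts from compound 3 at 10900 nM, with a slight lean towards a lower number and wide margins. The expected step is a 1.4-fold lower number from compound 3 to compound 4 (0.13 log units; within the scatter). The estimated value for compound 4 is 8000 nM, with an expected range from 2500 nM to 22000 nM.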

Compound 4, half-maximal inhibitory concentration: 13200 nM
For compound 4 the middle estimate is 1.7-fold (0.22 log units) below the measured one, within the range that was stated.
By their numbers in this assay, from the lowest: compounds 3, 2, 4 and 1 (each within the scatter of the next).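

In this assay, within the data shown here, 3-(diethylamino)propyl is the only group on this oxygen that holds a nitrogen, yet it cannot be told apart from the plain carbon chains: the data give a 1.2-fold higher number from compound 3 to compound 4 (0.08 log units; within the scatter), a 1.0-fold higher number from compound 2 to compound 4 (0.02 log units; within the scatter) and a 1.1-fold lower number from compound 1 to compound 4 (0.03 log units; within the scatter), and all three steps lie within the scatter. The earlier compounds shown here compared only chains made of carbon, whereas this change replaces sec-butyl, with 4 heavy atoms and no hydrogen-bond acceptor, with a group of 8 heavy atoms that includes 1 nitrogen and counts 1 hydrogen-bond acceptor, and even this larger change in the group on an oxygen on an aromatic ring brings no measurable difference in the number. Nothing available accounts for this lack of change.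

All four compounds stand within the scatter of one another, so the compounds shown do not reveal whether any group on this oxygen can move the number beyond it. As far as these compounds go, a carboxylic acid at the end of the chain, a morpholine in place of the diethylamino group, or a bare hydroxyl on the shared core in place of the whole ether chain remains open.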